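Compound 3 After Loss of Its (Furan-2-yl)carbonyl Group

The compounds below may be only part of what the source reports. "The series", "measured", "known", "first", "only" and "open" are said of these compounds alone.

Measured so far:
compound 1 `COc1cc(/C=C/C(=O)c2cccc(NC(=O)c3cc(Cl)cc(Cl)c3)c2)ccc1O`: 58%
compound 2 `COc1cc(/C=C/C(=O)c2cccc(NC(=O)c3ccc(Cl)cc3)c2)ccc1O`: 66%
compound 3 `COc1cc(/C=C/C(=O)c2cccc(NC(=O)c3ccco3)c2)ccc1O`: 100%

These numbers come from a functional assay on HUVEC cells (Homo sapiens) for inhibition, tested at 10 ug/mL; a lower number here means a weaker effect, a higher number a stronger effect of the compound at the concentration tested. Compound 3 stands highest of the three: the steps of a number 42 percentage points higher from compound 1 to compound 3 (beyond the scatter) and a number 34 percentage points higher from compound 2 to compound 3 (beyond the scatter) both lie beyond the scatter, whereas a number 8 percentage points higher from compound 1 to compound 2 (within the scatter) does not. Within the data shown here, compound 4 `COc1cc(/C=C/C(=O)c2cccc(N)c2)ccc1O` differs from compound 3 in one place. hydrogen in place of (furan-2-yl)carbonyl on a nitrogen on an aromatic ring No measured step removes the acyl group altogether; the two steps that bear on the change, a number 42 percentage points higher from compound 1 to compound 3 (beyond the scatter) and a number 34 percentage points higher from compound 2 to compound 3 (beyond the scatter), show only that exchanging one acyl group for another moves this assay by a large amount. Because compound 3 owes its top position to a number 34 percentage points higher from compound 2 to compound 3 (beyond the scatter), a drop is expected when that group is gone, giving the step of a number 50 percentage points lower from compound 3 to compound 4 (beyond the scatter). Compound 4 is therefore estimated at 50%, within 15% to 90%.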

Compound 4, a percentage reported as inhibition, at one concentration (the size of the read-out at that concentration, not a potency): 90%
Estimate against measurement, compound 4: 40 percentage points below; the range from low to high includes it.
By their numbers in this assay, from the lowest: compounds 1 and 2 (each within the scatter of the next); then compounds 4 and 3 (each within the scatter of the next).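

In this assay an acyl group on this nitrogen proves unnecessary for a strong effect: putting hydrogen in place of (furan-2-yl)carbonyl gives a number 10 percentage points lower from compound 3 to compound 4 (within the scatter) and leaves the free amino compound level with the furan amide. The same change gives a number 24 percentage points higher from compound 2 to compound 4 (beyond the scatter) and a number 32 percentage points higher from compound 1 to compound 4 (beyond the scatter) so the two chlorinated acyl groups go with lower numbers than no acyl group at all. Nothing available explains these differences. From the compounds shown here alone, it remains open whether a small acetyl group or a methyl group on this nitrogen would stay level with compound 3 and compound 4 or fall towards compound 1 and compound 2.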